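This account rests on a few compounds, and the source may have more. Where it says the series, first, only, none or still open, it means among the compounds named here.

Compound 2, with the structure `CO[C@]1(C)O[C@H]2[C@@H](OC/C=C/c3ccccc3)C=C(COC(C)=O)C(=O)[C@@H]2O[C@@]1(C)OC`, belongs to a small set of closely related compounds tested for their ability to block an enzyme. In an assay on isolated protein for inhibition of glutathione S-transferase P (Homo sapiens), read by spectrophotometry, with a stated time of 3 min (on this read-out higher numbers stand for weaker inhibition and lower numbers for stronger inhibition), compound 2 gives 58000 nM. Among the compounds with values here, its only measured relative is compound 1, with the structure `CCCCCCCCCCO[C@H]1C=C(COC(C)=O)C(=O)[C@@H]2O[C@@](C)(OC)[C@](C)(OC)O[C@@H]12`, which in this assay gives 36500 nM; the two values lie within the scatter of each other, so neither can be called the stronger inhibitor. Within the data shown here, the single measured step, a 1.6-fold higher number from compound 1 to compound 2 (0.20 log units; within the scatter), exchanges one side chain for another on an oxygen on a saturated carbon and leaves the read-out essentially unchanged.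

Compound 3, with the structure `CO[C@]1(C)O[C@H]2[C@@H](O)C=C(COC(C)=O)C(=O)[C@@H]2O[C@@]1(C)OC`, goes further: hydrogen in place of 3-phenylprop-2-en-1-yl on an oxygen on a saturated carbon, so the whole side chain on that oxygen is removed and a hydroxy group remains. Among the measured compounds shown here, no measured step covers the loss of the entire chain, so the only guidance is that swapping one chain for another made no difference beyond the scatter. A modest weakening is therefore expected, a 1.4-fold higher number from compound 2 to compound 3 (0.14 log units; within the scatter), but the uncertainty is wide. The estimate for compound 3 is 80000 nM, with a plausible range from 30000 nM to 250000 nM.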

Compound 3, half-maximal inhibitory concentration: 82500 nM
The estimate for compound 3 lay 1.0-fold (0.01 log units) below the measured number; low and high end bracket the measured number.
By their numbers in this assay, from the lowest: compounds 1, 2 and 3 (each within the scatter of the next, the first and the last beyond it).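

Taking the 3-phenylprop-2-en-1-yl group off the oxygen on a saturated carbon and leaving a hydroxy gives a 1.4-fold higher number from compound 2 to compound 3 (0.15 log units; within the scatter) in this assay, so on this read-out the loss of this entire side chain, aromatic ring included, cannot be told apart from no change. Within the data shown here, measured against the decyl group, the same bare hydroxy gives a 2.3-fold higher number from compound 1 to compound 3 (0.35 log units; beyond the scatter), a modest weakening and the first step at this position to pass the scatter, which shows that the group on this oxygen can make a small difference to inhibition, though only in this one comparison. Nothing available explains why the decyl group and the hydroxy differ by this amount.

What the three compounds leave open is whether a chain longer than decyl would lower the number further, or whether a short group such as methyl would fall within the scatter of the hydroxy. On these data alone, it is also open how a chain ending in an amine or a carboxylic acid would behave on this oxygen, and whether any change here could bring the number far below those seen so far.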